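A few compounds are considered here, and "the series" means these few. Any claim that something is new, unique, unknown or untested is made for them only; others in the source may bear on it.

Measured compounds:
compound 1, `Cc1cccc(-c2nc3cc(C)ccc3c(=O)[nH]2)c1`, gives 56.3%
compound 2, `CCN(CC)c1ccc2nc(-c3ccccc3OC(F)(F)F)[nH]c(=O)c2c1`, gives 0%
compound 3, `Cc1ccc2nc(-c3ccccc3F)[nH]c(=O)c2c1`, gives 36.3%

All three were tested in an assay on isolated protein for inhibition of DNA topoisomerase 1 (Homo sapiens), with a stated time of 30 min, tested at 20 uM; a higher number here means a stronger effect of the compound at the concentration tested, a lower number a weaker effect. Among them compound 1 stands highest. Its nearest neighbour is compound 3, which in this assay sits lower by a margin beyond the usual scatter. Compound 2 stands furthest away, with a still larger gap below compound 1, likewise beyond the scatter. No two of these compounds differ in only one place, so no single change can be read off between measured compounds; the numbers show only that compound 1 sits above the other two.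

Compound 4, `Cc1ccc2c(=O)[nH]c(-c3cccc(C(F)(F)F)c3)nc2c1`, has not yet been measured. Against compound 1 the change is trifluoromethyl in place of methyl on an aromatic carbon. The new group sits on an aromatic carbon of a six-membered aromatic ring of carbon only, meta to a large group. Within the data shown here, no measured pair shows what this exchange does, so the expectation rests on compound 1 alone. The step expected is a number 11.3 percentage points lower from compound 1 to compound 4 (beyond the scatter), small and most likely downward, though a result within the scatter of compound 1 would not surprise. Compound 4 is thus estimated at 45%, within a range from 15% to 75%.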

Compound 4, a percentage reported as inhibition, at one concentration (the size of the read-out at that concentration, not a potency): 93.6%
Beside the measured number, compound 4's estimate is 48.6 percentage points below it; measured number above the stated range.
By their numbers in this assay, from the lowest: compound 2; then compound 3; then compound 1; then compound 4.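

In this assay, the exchange of methyl for trifluoromethyl gives the first comparison among these compounds that differs in a single place: a number 37.3 percentage points higher from compound 1 to compound 4 (beyond the scatter), a large step. It shows that this position, on an aromatic carbon of a six-membered aromatic ring of carbon only and meta to a large group, is not indifferent to what it carries, and that here the group of four heavy atoms goes with more inhibition at the concentration tested than the group of one, with no hydrogen-bond donor or acceptor entering or leaving. The compounds offer no measurement that accounts for the size of this step.

This is one pair on one core, so it cannot tell whether trifluoromethyl would give a similar step on another carbon of that ring or on a core carrying different substituents. It also leaves open how other groups in this same place would compare with methyl and trifluoromethyl, such as a nitrile, an amine, a carboxylic acid or a longer alkyl chain.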